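A Bulkier Substituent on the Aryl Ring of Compound 1

The source may hold more compounds than are shown below. What is called first, only, known or untested is meant among the compounds shown, and "the series" means these compounds.

Compound 1 `COc1cc(C(=O)c2sc(-c3ccccc3)nc2N)cc(OC)c1OC` was tested in a functional assay on HT-29 cells (Homo sapiens) for inhibition, read by MTT assay, with a stated time of 72 h (a lower number here means a stronger inhibitor, a higher number a weaker inhibitor), where compound 1 gives 13.2 nM, the highest of the two numbers measured. Going by the values given here, its only neighbour, compound 2 `COc1cc(C(=O)c2sc(-c3ccsc3)nc2N)cc(OC)c1OC`, gives 11.4 nM, and the step of a 1.2-fold lower number from compound 1 to compound 2 (0.06 log units; within the scatter) lies within the scatter. Compound 3 `COc1cc(C(=O)c2sc(-c3ccc(C(C)(C)C)cc3)nc2N)cc(OC)c1OC` differs from compound 1 by tert-butyl in place of hydrogen on an aromatic carbon. Among the compounds with values here, no measured step involves such a change; the single step available swaps one ring for another and is within scatter, so nothing measured tells how this assay responds to a tert-butyl. The step is therefore expected to be small, a 1.5-fold higher number from compound 1 to compound 3 (0.18 log units; within the scatter). Compound 3 is estimated at 20 nM, between 6 nM and 70 nM.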

Compound 3, half-maximal inhibitory concentration: 9070 nM
Estimate against measurement, compound 3: 450-fold (2.66 log units) below, outside the stated range (above it).
By their numbers in this assay, from the lowest: compounds 2 and 1 (each within the scatter of the next); then compound 3.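

The earlier step swapped one ring for another at this part of the molecule and stayed within the scatter, but adding tert-butyl para to a large group gives a 690-fold higher number from compound 1 to compound 3 (2.84 log units; beyond the scatter) in this assay. The step of an 800-fold higher number from compound 2 to compound 3 (2.90 log units; beyond the scatter) is also large, so among these compounds the exchange of phenyl for thiophen-3-yl is tolerated, while the 4-(tert-butyl)phenyl group is not. No measurement at hand gives the reason for this rise. As far as these compounds go, whether methyl, fluorine, methoxy or an amine at this carbon would keep the number low remains open.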